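The source may hold more compounds than are shown below. What is called first, only, known or untested is meant among the compounds shown, and "the series" means these compounds.

Three measured compounds share one core and differ only in the length of the saturated chain on the ester. Compound 1 `CCCCCCCCCCCCCOC(=O)CCC(=O)N1CCN(CCCOc2cc3c(Nc4ccc(F)c(Cl)c4)ncnc3cc2OC)CC1` has the shortest chain of the three; in a functional assay on A549 cells (Homo sapiens) for cytotoxicity, read by MTT assay, with a stated time of 24 h, tested at 20 uM (on this read-out lower numbers stand for a stronger effect and higher numbers for a weaker effect at the one concentration tested), compound 1 gives 93.8%. Compound 2 `CCCCCCCCCCCCCCOC(=O)CCC(=O)N1CCN(CCCOc2cc3c(Nc4ccc(F)c(Cl)c4)ncnc3cc2OC)CC1` carries, relative to compound 1, (methyl in place of hydrogen on a saturated chain carbon, ten or more bonds along the chain from an oxygen next to a carbonyl group); in this assay compound 2 gives 92.3%, and the step between them is a number 1.5 percentage points lower from compound 1 to compound 2 (within the scatter). Compound 3 `CCCCCCCCCCCCCCCCCCCOC(=O)CCC(=O)N1CCN(CCCOc2cc3c(Nc4ccc(F)c(Cl)c4)ncnc3cc2OC)CC1` carries, relative to compound 1, (hexyl in place of hydrogen on a saturated chain carbon, ten or more bonds along the chain from an oxygen next to a carbonyl group); in this assay compound 3 gives 94.8%. The steps of a number 1 percentage points higher from compound 1 to compound 3 (within the scatter) and a number 2.5 percentage points higher from compound 2 to compound 3 (within the scatter) are likewise small, so all three numbers sit within the scatter of one another and none of the three can be called more or less active than the others. Across six added chain carbons the read-out did not move.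

Compound 4 `CCCCCCCCCCCCCCCCCCCCOC(=O)CCC(=O)N1CCN(CCCOc2cc3c(Nc4ccc(F)c(Cl)c4)ncnc3cc2OC)CC1` has not yet been measured in this assay. It differs from compound 3 by methyl in place of hydrogen on a saturated chain carbon, ten or more bonds along the chain from an oxygen next to a carbonyl group, the same change that was made from compound 1 to compound 2, where it produced a number 1.5 percentage points lower from compound 1 to compound 2 (within the scatter). Since the cores of compound 1 and compound 3 differ only by hexyl in place of hydrogen on a saturated chain carbon, ten or more bonds along the chain from an oxygen next to a carbonyl group and that difference left the read-out unchanged, the same change is expected to behave the same way here. Compound 4 is therefore expected to show a number 0.8 percentage points lower from compound 3 to compound 4 (within the scatter), because the earlier step of a number 1.5 percentage points lower from compound 1 to compound 2 (within the scatter) was within the scatter. The estimate for compound 4 is 94%, with a likely range from 86% to 100%.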

Compound 4, a percentage reported as activity, at one concentration (the size of the read-out at that concentration, not a potency): 90.8%
Compound 4: middle estimate off by 3.2 percentage points, on the high side, within the range that was stated.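

In this assay, adding the methyl to the longer chain gave a number 4 percentage points lower from compound 3 to compound 4 (within the scatter), which agrees with the earlier methyl step on the shorter chain: the same change on two cores in this assay, a number 1.5 percentage points lower (within the scatter) from compound 1 to compound 2 and a number 4 percentage points lower (within the scatter) from compound 3 to compound 4, 2.5 percentage points apart, within the scatter of two such steps The hexyl change can now also be read on two cores, and a number 1.5 percentage points lower from compound 2 to compound 4 (within the scatter) agrees with its earlier counterpart in the same way: the same change on two cores in this assay, a number 1 percentage points higher (within the scatter) from compound 1 to compound 3 and a number 1.5 percentage points lower (within the scatter) from compound 2 to compound 4, 2.5 percentage points apart, within the scatter of two such steps With a number 3 percentage points lower from compound 1 to compound 4 (within the scatter) as well, all the steps among the four compounds stay within the scatter, so both changes carried from one core to another without a detectable difference, but this does not show that either change has an effect of its own, and it says nothing about how they would behave on a core outside this chain series.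

The compounds shown leave open whether a butyl chain on the ester, or an amine or a carboxylic acid in place of the saturated chain, would give a read-out apart from these four values. They also leave open whether any of these chains would separate from the others at a concentration other than the single one tested.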